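Benzoyl to pivaloyl on the tetrazole urea series

A few compounds are considered here, and "the series" means these few. Any claim that something is new, unique, unknown or untested is made for them only; others in the source may bear on it.

Three compounds have numbers in an assay on microsomes from brain (strain Sprague-Dawley) for inhibition of Fatty-acid amide hydrolase 1 (Rattus norvegicus), read by HPLC, with stated times of 10 min and 45 min; on this read-out higher numbers stand for weaker inhibition and lower numbers for stronger inhibition. Compound 1 `O=C1C=CC(=O)N1Cc1ccc(Oc2ccccc2)cc1` gives 4900 nM. Compound 2 `CN(C)C(=O)n1nnc(-c2ccc(Oc3cccc(Cl)c3)cc2)n1` gives 9 nM. Compound 3 `Cc1cc(C(=O)c2ccccc2)c(C)n1-c1ccc(-c2nnn(C(=O)N(C)C)n2)cc1` gives 16 nM, which stands second highest of the three; compound 2 lies within the scatter of it, while compound 1 sits far beyond the scatter on the weaker side. Compound 4 `Cc1cc(C(=O)C(C)(C)C)c(C)n1-c1ccc(-c2nnn(C(=O)N(C)C)n2)cc1` differs from compound 3 by tert-butyl in place of phenyl on a carbonyl carbon. Among the measured compounds shown here, no step of this kind has been measured, so the expectation rests on compound 3 alone. A modest weakening is expected, roughly a 2.5-fold higher number from compound 3 to compound 4 (0.40 log units; beyond the scatter), though a result within the scatter would not surprise. Compound 4 is therefore estimated at 40 nM, with a range of 10 nM to 160 nM.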

Compound 4, half-maximal inhibitory concentration: 29 nM
For compound 4 the middle estimate is 1.4-fold (0.14 log units) above the measured one, within the range that was stated.
By their numbers in this assay, from the lowest: compounds 2, 3 and 4 (each within the scatter of the next, the first and the last beyond it); then compound 1.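

At this position, on a carbonyl carbon whose other neighbour is aromatic carbon, phenyl gives way to tert-butyl with a 1.8-fold higher number from compound 3 to compound 4 (0.26 log units; within the scatter) in this assay. An aromatic ring on this carbonyl is therefore not needed to keep the number in this range, which compound 3 alone could not show. Nothing available here explains this result. Open, going by these compounds, is how far the group on this carbonyl carbon can shrink or change, for instance to methyl, a longer chain such as n-butyl, or a group carrying an amine or a carboxylic acid.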